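The compounds below may be only part of what the source reports. "The series", "measured", "known", "first", "only" and "open" are said of these compounds alone.

Measured so far:
- compound 1 `Cc1cccc(Oc2ccnc(N3CCC[C@H]3C(=O)NCCCn3ccnc3)n2)c1`: in an assay on isolated protein for inhibition of calcium/calmodulin-dependent protein kinase type IV (Homo sapiens), read by HTRF, tested at 10 uM (on this read-out lower numbers stand for less inhibition and higher numbers for more inhibition at the one concentration tested (going by the name of the read-out)), compound 1 gives 0%
- compound 2 `CN(CCCn1ccnc1)C(=O)[C@@H]1CCCN1c1nccc(Nc2ccccc2)n1`: in this assay compound 2 gives 0%

Compound 2 stands level with compound 1 at the digits reported; the two values lie within the usual scatter of one another, so neither is ranked above the other. Compound 3 `CN(C)CC(C)(C)CNC(=O)[C@@H]1CCCN1c1nccc(Nc2ccccc2)n1` has not yet been measured. It keeps the core of compound 2 and changes only the substituent on the amide: (2-((dimethylamino)methyl)-2-methylpropyl)amino in place of (3-(1H-imidazol-1-yl)propyl)(methyl)amino on a carbonyl carbon. For the measured compounds named here, no step between measured compounds is available to anchor the size of this change, and both measured values sit at the bottom of the read-out. The step from compound 2 to compound 3 in this assay is therefore expected to be a number 2 percentage points higher from compound 2 to compound 3 (within the scatter), that is, none beyond the scatter. Compound 3 is estimated to give 2% in this assay, with a range from -8% to 15%.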

Compound 3, a percentage reported as inhibition, at one concentration (the size of the read-out at that concentration, not a potency): 0%
For compound 3 the middle estimate is 2 percentage points above the measured one, within the range that was stated.
By their numbers in this assay, from the lowest: compounds 1, 2 and 3 (each within the scatter of the next).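

In this assay, putting (2-((dimethylamino)methyl)-2-methylpropyl)amino in place of (3-(1H-imidazol-1-yl)propyl)(methyl)amino on a carbonyl carbon gives no change at the digits printed from compound 2 to compound 3 (within the scatter). So at this place the five-membered aromatic ring can go, with no ring entering, and the read-out stays at the bottom, which means that neither group can be told from the other here and that this step reveals no preference between them. No evidence available here bears on a reason for this result.

Open, on these data alone, is whether any group on this carbonyl carbon, such as a piperazine or a carboxylic acid, would lift the read-out off the bottom. Also open, as far as these compounds go, is whether a change to the shared core, rather than to the amide substituent, would do so.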